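Swapping Chloro for Sulfamoyl: Cytotoxicity in Liver Cells

The source may report more compounds than this note shows. Statements on the series, on what has been measured and on what is new or still open speak of the compounds shown alone.

Compound 1 `COc1cc2c(=O)c(C(=O)c3ccc(C)cc3)cn(Cc3ccc(Cl)cc3)c2cc1OC` was tested in an ADME assay on Huh-7 cells (Homo sapiens) for cytotoxicity (a lower number here means a stronger inhibitor of growth, a higher number a weaker inhibitor of growth), and gave 15500 nM. Two related compounds give context. Compound 3 `COc1cc2c(=O)c(C(=O)OCc3ccc(C)cc3)cn(Cc3ccc(C(F)(F)F)cc3F)c2cc1OC` shows 20000 nM in this assay, and the gap between compound 1 and compound 3 lies within the usual scatter of this kind of measurement, so the two cannot be ranked against each other. Compound 2 `CN1CCN(c2cc3c(cc2F)c(=O)c(NC(=O)NCc2ccc(Cl)cc2)cn3Cc2ccc(Cl)cc2)CC1` was reported in this assay as "not active" (no number reported), without a number.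

Compound 4 `COc1cc2c(=O)c(C(=O)c3ccc(C)cc3)cn(Cc3ccc(S(N)(=O)=O)cc3)c2cc1OC` has not yet been measured. It differs from compound 1 in one place: sulfamoyl in place of chloro on an aromatic carbon. Going by the values given here, no measured pair shows this same change, so its effect on growth inhibition is unknown here. With only compound 1 as a reference, and its value of 15500 nM already indicating weak growth inhibition, the step is expected to be small, if anything toward a higher number, as a 1.4-fold higher number from compound 1 to compound 4 (0.15 log units; within the scatter). Compound 4 is therefore estimated at 22000 nM, within a range from 9000 nM to 60000 nM.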

Compound 4, concentration for 50% growth inhibition: > 25000 nM
Compound 4 was reported as a limit; the forecaster's own chance of this, stated with the estimate: 35%; at least 1.1-fold (0.05 log units) between middle value and limit.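

Compound 4 is reported in this assay only as a limit, > 25000 nM, and not as a single number. Putting sulfamoyl in place of chloro, para to a large group, gives an at least 1.6-fold higher number from compound 1 to compound 4 (0.20 log units; that floor lies within the scatter), so this swap at this position produces no lower number, although the step cannot be called a real weakening on the printed floor alone. How far the true value of compound 4 lies from compound 1 stays hidden, and the reading ends at the limit of the assay: the limit of > 25000 nM in this assay, at which 1 of the 4 values shown sits.

The compounds shown leave open how an amine or a carboxylic acid at this same position on the benzyl ring would compare with chloro and sulfamoyl. Going by these compounds alone, they also leave open whether the same swap would give a similar step on a different core, as this is the only pair showing it.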